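Methyl for Nitro on a Second Core

The compounds below may be only part of what the source reports. "The series", "measured", "known", "first", "only" and "open" are said of these compounds alone.

Of the compounds shown here, three with a shared core have been measured in a functional assay on A549 cells (Homo sapiens) for inhibition, read by MTT assay, with a stated time of 72 h; a lower number here means a stronger inhibitor, a higher number a weaker inhibitor. Compound 1 `O=[N+]([O-])c1ccc(-c2nnc(SCCCN3CCN(c4nc5ccccc5o4)CC3)o2)cc1` gives 90800 nM in this assay. Compound 2 `Cc1ccc(-c2nnc(SCCCN3CCN(c4nc5ccccc5o4)CC3)o2)cc1` differs from compound 1 by methyl in place of nitro on an aromatic carbon; in this assay compound 2 gives 106000 nM, and this change made a step of a 1.2-fold higher number from compound 1 to compound 2 (0.07 log units; within the scatter). Compound 3 `O=[N+]([O-])c1ccc(-c2nnc(SCCCN3CCN(c4nc5ccccc5s4)CC3)o2)cc1` differs from compound 1 in its core, by 1,3-benzothiazol-2-yl in place of 1,3-benzoxazol-2-yl on an amine nitrogen in a ring; in this assay compound 3 gives 96600 nM, and that change made a step of a 1.1-fold higher number from compound 1 to compound 3 (0.03 log units; within the scatter). All three numbers lie within the scatter of one another, so no order among them can be stated.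

Compound 4 `Cc1ccc(-c2nnc(SCCCN3CCN(c4nc5ccccc5s4)CC3)o2)cc1` has not yet been measured in this assay. It differs from compound 3 by methyl in place of nitro on an aromatic carbon. Among the measured compounds shown here, this is the same change as the one from compound 1 to compound 2, now made on the core of compound 3, and the surroundings of the place are described in the same words in both cases.

Because the step of a 1.2-fold higher number from compound 1 to compound 2 (0.07 log units; within the scatter) was within the scatter, the corresponding step on the other core is expected to be small as well, and compound 4 is estimated to show a step of a 1.2-fold higher number from compound 3 to compound 4 (0.06 log units; within the scatter) from compound 3. Resting on the value of compound 3, 96600 nM, compound 4 is estimated at 112000 nM in this assay, with an expected range from 60000 nM to 220000 nM.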

Compound 4, half-maximal inhibitory concentration: 53900 nM
Estimate against measurement, compound 4: 2.1-fold (0.32 log units) above; measured number outside the range, below it.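

In this assay, methyl in place of nitro on the core of compound 3 gave a 1.8-fold lower number from compound 3 to compound 4 (0.25 log units; within the scatter), and this step does not differ beyond the scatter from the one made on the core of compound 1: the same change on two cores in this assay, a 1.2-fold higher number (0.07 log units; within the scatter) from compound 1 to compound 2 and a 1.8-fold lower number (0.25 log units; within the scatter) from compound 3 to compound 4, 2.1-fold (0.32 log units) apart, within the scatter of two such steps. The exchange of 1,3-benzoxazol-2-yl for 1,3-benzothiazol-2-yl, read on the two methyl compounds, gave a 2.0-fold lower number from compound 2 to compound 4 (0.29 log units; within the scatter), and it likewise agrees within the scatter with the same exchange read on the two nitro compounds: the same change on two cores in this assay, a 1.1-fold higher number (0.03 log units; within the scatter) from compound 1 to compound 3 and a 2.0-fold lower number (0.29 log units; within the scatter) from compound 2 to compound 4, 2.1-fold (0.32 log units) apart, within the scatter of two such steps. The four compounds are therefore compatible with the change carrying from one core to the other, but they do not prove that it does: with one pair on each core and every step within the scatter, they can neither establish a shared effect of the change nor exclude a modest dependence on the core.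

As far as these compounds go, it remains open whether the step would stay this small with other groups at the same place, such as an amine or a carboxylic acid, or with a longer chain on the sulfur. From the compounds shown here alone, it also remains open whether either step would hold on other cells or in another kind of assay.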